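This account rests on a few compounds, and the source may have more. Where it says the series, first, only, none or still open, it means among the compounds named here.

Compound 1, `CSc1ccc2c(c1)c(O)c(C(=O)N(C)c1ccccc1)c(=O)n2C`, stands highest of the two numbers measured in a functional assay on the whole organism for inhibition, with Mus musculus as the target, at a dose of 32 mg/kg by the oral route; on this read-out higher numbers stand for more inhibition at the one dose given (going by the name of the read-out) and lower numbers for less inhibition: there compound 1 gives 100%. Compound 2, `CN(C(=O)c1c(O)c2cc(S(C)(=O)=O)ccc2n(C)c1=O)c1ccccc1`, gives 0% in this assay. Among the measured compounds shown here, the only measured step, a number 100 percentage points lower from compound 1 to compound 2 (beyond the scatter), changes the group on the shared core, not the phenyl ring on the amide.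

Compound 3, `CSc1ccc2c(c1)c(O)c(C(=O)N(C)c1ccc(F)cc1)c(=O)n2C`, differs from compound 1 by fluoro in place of hydrogen on an aromatic carbon, on an aromatic carbon of the six-membered carbon ring, para to a large group. For the measured compounds named here, no measured step touches this ring, so nothing measured bears directly on the change; the step from compound 1 to compound 2 sits at another place and is not a guide. The expectation for compound 3 is therefore a step of a number 15 percentage points lower from compound 1 to compound 3 (beyond the scatter) in this assay, that is, none beyond the scatter, with a wide range to cover the lack of any anchoring step. Compound 3 is estimated at 85%, between 45% and 100%.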

Compound 3, a percentage reported as inhibition, in the whole organism at one dose (the size of the read-out at that dose, not a potency): 100%
Estimate against measurement, compound 3: 15 percentage points below; the measured number falls inside the stated range.
By their numbers in this assay, from the lowest: compound 2; then compounds 1 and 3 (each within the scatter of the next).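

Among the compounds shown here, on the phenyl ring of the amide, the change from phenyl to 4-fluorophenyl gives no change at the digits printed from compound 1 to compound 3 (within the scatter) in this assay and so adds a first reading at this ring, since the only earlier step changed the group on the shared core. At this place, para to a large group, fluoro in place of hydrogen brings no loss visible at the one dose given. Nothing at hand bears on why the number holds.

A single dose leaves open whether compound 1 and compound 3 would separate at a lower dose. Also open, as far as these compounds go, is whether another group at this place, such as methoxy, an amine or a carboxylic acid, would hold the number, and whether fluoro would change anything with the methylsulfonyl group of compound 2 on the core.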